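The compounds below may be only part of what the source reports. "The series", "measured", "known", "first", "only" and "open" are said of these compounds alone.

Among the compounds with values here, in a functional assay on PC-3 cells (Mus musculus) for cytotoxicity against PC-3 (Homo sapiens) (on this read-out lower numbers stand for stronger inhibition and higher numbers for weaker inhibition), compound 3 `CCCN(CCC)c1c([N+](=O)[O-])cc(S(=O)(=O)Nc2ccc(Cl)c(Cl)c2)cc1[N+](=O)[O-]` gives 15000 nM and sits at the low end of the three numbers measured so far. It is level within the scatter with compound 1 `CCCN(CCC)c1c([N+](=O)[O-])cc(S(=O)(=O)Nc2ccc(Cl)cc2)cc1[N+](=O)[O-]` at 16000 nM and clearly under compound 2 `CCCN(CCC)c1c([N+](=O)[O-])cc(S(=O)(=O)Nc2cccc(OC)c2)cc1[N+](=O)[O-]` at 36000 nM on this read-out.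

The still unmeasured compound 4 `CCCN(CCC)c1c([N+](=O)[O-])cc(S(=O)(=O)N(C)c2ccccc2)cc1[N+](=O)[O-]` has methyl(phenyl)amino in place of (3,4-dichlorophenyl)amino on a sulfonyl sulfur and so differs in both the aromatic ring and the sulfonamide nitrogen. Within the data shown here, two measured steps bear on the ring. Adding chloro in place of hydrogen gave a 1.1-fold lower number from compound 1 to compound 3 (0.03 log units; within the scatter) and stayed within the scatter. Replacing 3-methoxyphenyl, the one measured ring without chloro, by 3,4-dichlorophenyl gave a 2.4-fold lower number from compound 2 to compound 3 (0.38 log units; beyond the scatter) and was modest. Among the measured compounds shown here, no measured compound carries a methyl group on the sulfonamide nitrogen, so that part of the change has no guide and widens the range.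

A modest move toward a higher number in this assay is therefore expected, with no large step in either direction. The expected change is a 1.7-fold higher number from compound 3 to compound 4 (0.22 log units; within the scatter) on this estimate. For compound 4 the estimated value is 25000 nM within an expected range of 10000 nM to 60000 nM in this assay.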

Compound 4, half-maximal inhibitory concentration: > 100000 nM
Compound 4 ended at the assay's limit (the forecaster's own chance of this, stated with the estimate: 15%); middle value at least 4.0-fold (0.60 log units) from the limit.
By their numbers in this assay, from the lowest: compounds 3 and 1 (each within the scatter of the next); then compound 2. At a limit, above all of these: compound 4.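

Compound 4 sits at a limit of the read-out in this assay, and that limit is not a number: the limit of > 100000 nM in this assay, at which 1 of the 4 values shown sits. Measured against the three compounds that keep the hydrogen on the sulfonamide nitrogen, the change gives an at least 6.6-fold higher number from compound 3 to compound 4 (0.82 log units; beyond the scatter), an at least 6.2-fold higher number from compound 1 to compound 4 (0.79 log units; beyond the scatter) and an at least 2.7-fold higher number from compound 2 to compound 4 (0.44 log units; beyond the scatter), so all three stand clear of compound 4 despite their different rings. Within the data shown here, the first two of these steps exceed any step among the earlier compounds, which showed only small or modest differences when the ring alone changed, so this position responds more strongly to methyl(phenyl)amino than those ring changes suggested.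

Because methyl(phenyl)amino brings a methyl on the nitrogen and also a ring without chloro or methoxy, the compounds shown leave open which of the two parts accounts for the rise, and the limit itself gives no cause. A plain phenylamino group with the hydrogen kept, and a 3,4-dichlorophenyl ring with methyl or a longer chain such as ethyl or propyl on that nitrogen, would tell these parts apart.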